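A few compounds are considered here, and "the series" means these few. Any claim that something is new, unique, unknown or untested is made for them only; others in the source may bear on it.

Working notes on the shared core of compound 1 `COc1cccc(/C=C2\CCC/C(=C\c3ccccc3Cl)C2=O)c1OC`. In a functional assay on SW-620 cells (Homo sapiens) for cytotoxicity, read by MTT assay, with a stated time of 72 h (on this read-out higher numbers stand for weaker inhibition and lower numbers for stronger inhibition), compound 1 gives 10300 nM, the lower of the two plain numbers in hand, with compound 2 `COc1cccc(/C=C2\CCC/C(=C\c3ccc(Br)cc3)C2=O)c1OC` nearest at 11100 nM. Compound 3 `COc1cccc(/C=C2\CCC/C(=C\c3ccc(O)cc3)C2=O)c1OC` gives only a limit of the assay, > 20000 nM. Across the halogen swap the change is a 1.1-fold higher number from compound 1 to compound 2 (0.03 log units; within the scatter). Toward the hydroxy analogue the change is an at least 1.9-fold higher number from compound 1 to compound 3 (0.28 log units; that floor lies within the scatter), and likewise an at least 1.8-fold higher number from compound 2 to compound 3 (0.25 log units; that floor lies within the scatter); both floors rest on (the limit of > 20000 nM in this assay, at which 1 of the 3 values shown sits).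

Compound 4 `COc1cc(/C=C2\CCC/C(=C\c3cccc(OC)c3OC)C2=O)ccc1O` carries the change (4-hydroxy-3-methoxyphenyl in place of 2-chlorophenyl on a double-bonded chain carbon bound to a double-bonded ring carbon). Going by the values given here, the measured step that bears on it is the one to compound 3, which carries the 4-hydroxyphenyl that the 4-hydroxy-3-methoxyphenyl of compound 4 closely resembles: an at least 1.9-fold higher number from compound 1 to compound 3 (0.28 log units; that floor lies within the scatter), a floor only. The step in this assay is therefore expected to run toward a higher number, of at least the size seen for compound 3, and a report of the limit alone is the likeliest outcome. Compound 4 is expected at 22000 nM, within 9000 nM to 50000 nM, which means a 2.1-fold higher number from compound 1 to compound 4 (0.33 log units; beyond the scatter).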

Compound 4, half-maximal inhibitory concentration: 8600 nM
Compound 4: middle estimate off by 2.6-fold (0.41 log units), on the high side; measured number outside the range, below it.
By their numbers in this assay, from the lowest: compounds 4, 1 and 2 (each within the scatter of the next). At a limit, above all of these: compound 3.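

In this assay, a hydroxy group on this aryl ring does not by itself set the result, since the 4-hydroxy-3-methoxyphenyl of compound 4 stays level with both halogenated aryl groups: a 1.2-fold lower number from compound 1 to compound 4 (0.08 log units; within the scatter) and a 1.3-fold lower number from compound 2 to compound 4 (0.11 log units; within the scatter). Going by these compounds alone, only one step in the set is beyond the scatter, the methoxy in place of hydrogen on an aromatic carbon, an at least 2.3-fold lower number from compound 3 to compound 4 (0.36 log units; beyond the scatter), so the 4-hydroxyphenyl and the 4-hydroxy-3-methoxyphenyl, though close in structure, can be told apart at this position. The true size of that step remains unknown, as it is a floor set by a limit for compound 3: the limit of > 20000 nM in this assay, at which 1 of the 4 values shown sits.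

Still open, from the compounds shown here alone, is whether the methoxy needs the hydroxy with it, which an aryl group carrying methoxy alone would test, and whether an amine or a carboxylic acid in place of the hydroxy would follow compound 3 or compound 4. Also open, going by these compounds, is whether any group on this double-bonded chain carbon can move the number clearly lower than compound 4, since compounds 1, 2 and 4 lie within the scatter of one another.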